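The source may hold more compounds than are shown below. What is called first, only, known or untested is meant among the compounds shown, and "the series" means these compounds.

In a functional assay on V79 cells (Cricetulus griseus) for cytotoxicity, read by colony formation (on this read-out lower numbers stand for stronger inhibition and higher numbers for weaker inhibition), compound 3 (`COc1c(N2CCC(C)(N)C2)c(F)cc2c(=O)c(C(=O)O)cn(C3CC3)c12`) gives 38 ug/mL, within the scatter of compound 2 (`NC1CCN(c2c(F)cc3c(=O)c(C(=O)O)cn(C4CC4)c3c2C(F)(F)F)CC1`) at 20 ug/mL. Compound 1 (`CC1CN(c2c(F)cc3c(=O)c(C(=O)O)cn(C4CC4)c3c2C(F)(F)F)CC(C)N1`) gives only a limit, > 500 ug/mL. Compound 4 (`CC1(N)CCN(c2c(F)cc3c(=O)c(C(=O)O)cn(C4CC4)c3c2C(F)(F)F)C1`) keeps the 3-amino-3-methylpyrrolidin-1-yl group of compound 3 and has trifluoromethyl in place of methoxy on an aromatic carbon. For the measured compounds named here, no measured step makes this exchange. Going by the values given here, the one measured step, an at least 25-fold lower number from compound 1 to compound 2 (1.39 log units; beyond the scatter), is large, but it replaces 3,5-dimethylpiperazin-1-yl with 4-aminopiperidin-1-yl while trifluoromethyl stays in place. Compound 2, which also carries trifluoromethyl, gives 20 ug/mL, so no shift beyond the scatter is expected in this assay. The expected change is a 1.3-fold lower number from compound 3 to compound 4 (0.10 log units; within the scatter). For compound 4 the estimate is 30 ug/mL, with an expected range from 9 ug/mL to 110 ug/mL.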

Compound 4, half-maximal inhibitory concentration: 110 ug/mL
For compound 4 the middle estimate is 3.7-fold (0.56 log units) below the measured one; low and high end bracket the measured number.
By their numbers in this assay, from the lowest: compounds 2 and 3 (each within the scatter of the next); then compound 4. At a limit, above all of these: compound 1.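

In this assay, trifluoromethyl in place of methoxy, ortho to a 3-amino-3-methylpyrrolidin-1-yl group, now has a measured step, a 2.9-fold higher number from compound 3 to compound 4 (0.46 log units; beyond the scatter), so this position affects the read-out. With trifluoromethyl held in place, 3-amino-3-methylpyrrolidin-1-yl in place of 4-aminopiperidin-1-yl also counts, with a 5.5-fold higher number from compound 2 to compound 4 (0.74 log units; beyond the scatter). The remaining step, an at least 4.5-fold lower number from compound 1 to compound 4 (0.65 log units; beyond the scatter), rests on a limit and gives only a bound: the limit of > 500 ug/mL in this assay, at which 1 of the 4 values shown sits.

As far as these compounds go, whether the methoxy exchange gives the same step with 4-aminopiperidin-1-yl stays open. So does the effect of a chlorine or a nitrile at this position.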